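Swapping trifluoromethyl for chloro on a weakly active urea

The compounds below may be only part of what the source reports. "The series", "measured", "known", "first", "only" and "open" are said of these compounds alone.

Compound 2 `COc1cc2cc(Oc3ccc(NC(=O)Nc4ccc(Cl)c(C(F)(F)F)c4)cc3)c(C)nc2cc1OC` and compound 1 `COc1cc2cc(Oc3ccc(NC(=O)Nc4cccc(C(F)(F)F)c4)cc3)c(C)nc2cc1OC` share one core and differ only in a single chloro group. In a functional assay on SF-539 cells (Homo sapiens) for inhibition, read by sulforhodamine B assay, with a stated time of 48 h (on this read-out higher numbers stand for weaker inhibition of growth and lower numbers for stronger inhibition of growth), compound 2 gives 8390 nM, and compound 1 gives 8740 nM; the two numbers lie within the usual scatter of each other, as the step of a 1.0-fold lower number from compound 1 to compound 2 (0.02 log units; within the scatter) shows, so neither can be called more active. Compound 3 `COc1cc2cc(Oc3ccc(NC(=O)Nc4ccc(Cl)c(Cl)c4)cc3)c(C)nc2cc1OC` arises from compound 2 by the change (chloro in place of trifluoromethyl on an aromatic carbon). Within the data shown here, the only measured step, that from compound 1 to compound 2, concerns a different position and a different group, and it was flat, so it gives no direct guide to this exchange and suggests that modest changes on this part of the molecule leave this assay largely unmoved. No step beyond the scatter is therefore expected, with a 1.0-fold lower number from compound 2 to compound 3 (0.02 log units; within the scatter) as the anticipated shift. Compound 3 is estimated at 8000 nM, with a plausible range from 3000 nM to 20000 nM.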

Compound 3, concentration for total growth inhibition: 22300 nM
Beside the measured number, compound 3's estimate is 2.8-fold (0.45 log units) below it; measured number outside the range, above it.
By their numbers in this assay, from the lowest: compounds 2 and 1 (each within the scatter of the next); then compound 3.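

The trifluoromethyl group at this place turns out not to be freely exchangeable: in this assay the swap to chloro gives a 2.7-fold higher number from compound 2 to compound 3 (0.42 log units; beyond the scatter) and so modestly weakens growth inhibition. The 3,4-dichlorophenyl group in place of 3-(trifluoromethyl)phenyl gives a similar result, with a 2.6-fold higher number from compound 1 to compound 3 (0.41 log units; beyond the scatter) as the step, so among these three compounds only the steps that lose trifluoromethyl go beyond the scatter, while adding chloro alone leaves the number within it. No available evidence says why the number rises.

On these data alone, whether a nitrile, a methyl group or an amine at this place would keep the number close to that of compound 2 or push it higher stays open. So does the effect of a longer chain there, such as an ethyl or propyl group.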